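Difluoromethoxy in Place of Methyl on Compound 2

The source may hold more compounds than are shown below. What is called first, only, known or untested is meant among the compounds shown, and "the series" means these compounds.

Of the compounds shown here, two have so far been tested in an assay on cells for inhibition of S-adenosylmethionine decarboxylase proenzyme (Homo sapiens), read by mass spectrometry, at pH 7.2; on this read-out lower numbers stand for stronger inhibition and higher numbers for weaker inhibition. Compound 1 `Cc1cc(Nc2cc(Cl)cc(Cl)c2)ncn1` gives only a limit of the assay, > 180000 nM, and no number. Compound 2 `Cc1cc(Nc2cc(Cl)c(C)c(Cl)c2)nc(N)n1` also gives only a limit, > 63000 nM. Compound 2 therefore stands at one of two limits, (the limit of > 63000 nM in this assay, at which 1 of the 2 values shown sits), while the other reading sits at the limit of > 180000 nM in this assay, at which 1 of the 2 values shown sits; neither value can be ordered against the other.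

Compound 3 `Cc1cc(Nc2cc(Cl)c(OC(F)F)c(Cl)c2)nc(N)n1` differs from compound 2 by difluoromethoxy in place of methyl on an aromatic carbon. No step between measured compounds is shown, so nothing points to a direction for this change. No step beyond the scatter is expected in this assay, and the step from compound 2 to compound 3 is estimated as a step that the limit leaves unreadable from compound 2 to compound 3. For compound 3 the estimated value in this assay is 100000 nM, with a range from 20000 nM to 500000 nM, and a limit rather than a number is expected to be the likelier report.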

Compound 3, half-maximal inhibitory concentration: > 63000 nM
Compound 3 was reported as a limit; the forecaster's own chance of this, stated with the estimate: 75%; the middle value is on the limit's open side.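

Within the data shown here, compound 2 and compound 3 are both reported only as limits in this assay, and no step between them can be read. The compounds shown leave open how difluoromethoxy and methyl compare at this place, and what number compound 1, compound 2 or compound 3 would give.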